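Removing One Bromo from Compound 1

The source may hold more compounds than are shown below. What is called first, only, known or untested is meant among the compounds shown, and "the series" means these compounds.

In a functional assay on NALM-6 cells (Homo sapiens) for cytotoxicity, read by luminescence and CellTiter-Glo, with a stated time of 3 days (on this read-out higher numbers stand for weaker inhibition and lower numbers for stronger inhibition), compound 1 `O=C(Nc1cc(C(F)(F)F)cc(C(F)(F)F)c1)c1cc(Br)c(-c2ccccc2)cc1O` gives 840 nM. Compound 3 `N#Cc1cc(Cl)ccc1NC(=O)c1ccc2cccnc2c1O`, which has a different structure, gives 280 nM. Compound 1 therefore has the higher of the two numbers, and the gap lies beyond the usual scatter. For compound 2 `N#Cc1cccc(NC(=O)c2cc(F)ccc2O)c1`, the entry reads "not determined" (no result reported), so it cannot be ranked.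

The next compound to be tested is compound 4 `O=C(Nc1cc(C(F)(F)F)cc(C(F)(F)F)c1)c1ccc(-c2ccccc2)cc1O`. It has hydrogen in place of bromo on an aromatic carbon, ortho to a phenyl group and para to a hydroxy group (hydrogen in place of bromo on an aromatic carbon). The rest of the structure stays the same.

Among the compounds with values here, no measured pair here differs in only one place, so the data do not show what such a swap does. The expectation therefore starts from compound 1 at 840 nM and is cautious: no step beyond the scatter in this assay, with a slight lean towards a higher number. The expected change is a 1.2-fold higher number from compound 1 to compound 4 (0.08 log units; within the scatter). Compound 4 is estimated at 1000 nM, with an expected range from 350 nM to 3000 nM.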

Compound 4, half-maximal inhibitory concentration: 1580 nM
For compound 4 the middle estimate is 1.6-fold (0.20 log units) below the measured one; low and high end bracket the measured number.
By their numbers in this assay, from the lowest: compound 3; then compounds 1 and 4 (each within the scatter of the next).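

Within the data shown here, compounds 1 and 4 form the first pair here that differs in only one place, and in this assay the swap of bromo for hydrogen gives a 1.9-fold higher number from compound 1 to compound 4 (0.27 log units; within the scatter). At this aromatic carbon, ortho to a phenyl group and para to a hydroxy group, the bromo can therefore be replaced by hydrogen with no step beyond the scatter, so this read-out does not separate the two compounds. No measurement shown bears on what lies behind this result.

As far as these compounds go, whether another group on this carbon, such as chloro, methoxy, an amine or a carboxylic acid, would move the number beyond the scatter remains open. This single pair also says nothing about how the same swap would behave elsewhere on the core.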